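Thiophene-to-pyrrole swap on the enone carbonyl of a quinoline series

The compounds below may be only part of what the source reports. "The series", "measured", "known", "first", "only" and "open" are said of these compounds alone.

Measured so far in a functional assay on MDA-MB-231 cells (Homo sapiens) for antiproliferative activity, read by XTT assay, with a stated time of 72 h; on this read-out higher numbers stand for weaker inhibition and lower numbers for stronger inhibition:
compound 1 `COc1ccc(-c2cc3ccccc3nc2/C=C/C(=O)c2ccc(O)cc2)cc1`: 6350 nM
compound 2 `COc1ccc(-c2cc3ccccc3nc2/C=C/C(=O)c2ccc(OC)cc2OC)cc1`: 3210 nM
compound 3 `COc1ccc(-c2cc3ccccc3nc2/C=C/C(=O)c2cccs2)cc1`: 410 nM

Compound 3 stands lowest of the three, separated from both others beyond the scatter: the step of a 15-fold lower number from compound 1 to compound 3 (1.19 log units; beyond the scatter) is large, the step of a 7.8-fold lower number from compound 2 to compound 3 (0.89 log units; beyond the scatter) modest, while a 2.0-fold lower number from compound 1 to compound 2 (0.30 log units; within the scatter) stays within the scatter. Compound 4 `COc1ccc(-c2cc3ccccc3nc2/C=C/C(=O)c2ccc[nH]2)cc1` carries 1H-pyrrol-2-yl in place of thiophen-2-yl on a carbonyl carbon. For the measured compounds named here, no measured step exchanges one five-membered ring for another; the two steps into compound 3 only show that thiophen-2-yl gives lower numbers than either six-membered ring. Compound 4 is therefore expected near compound 3, with a 2.0-fold higher number from compound 3 to compound 4 (0.29 log units; within the scatter) as a step not clearly beyond the scatter. The estimate for compound 4 in this assay is 800 nM, within 250 nM to 2500 nM.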

Compound 4, half-maximal inhibitory concentration: > 10000 nM
Compound 4: no number, only a limit; the forecaster's own chance of this, stated with the estimate: 5%; middle value at least 12-fold (1.09 log units) from the limit.
By their numbers in this assay, from the lowest: compound 3; then compounds 2 and 1 (each within the scatter of the next). At a limit, above all of these: compound 4.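

In this assay, thiophen-2-yl and 1H-pyrrol-2-yl on the carbonyl carbon are not interchangeable, although both are five-membered aromatic rings with 1 hetero atom: an at least 24-fold higher number from compound 3 to compound 4 (1.38 log units; beyond the scatter). The low numbers of compound 3 therefore do not extend to five-membered rings in general, since an at least 3.1-fold higher number from compound 2 to compound 4 (0.49 log units; beyond the scatter), while an at least 1.5-fold higher number from compound 1 to compound 4 (0.19 log units; that floor lies within the scatter) gives no reliable separation. The result for compound 4 is a limit, so these steps are floors: the limit of > 10000 nM in this assay, at which 1 of the 4 values shown sits.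

On these data alone, whether furan-2-yl or 1-methyl-1H-pyrrol-2-yl on the same carbonyl carbon would track compound 3 or compound 4 remains open. How far compound 4 lies beyond its limit is also unknown.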